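Compound 1 to compound 3: methyl to ethyl

The compounds below may be only part of what the source reports. "The series", "measured", "known", "first", "only" and "open" are said of these compounds alone.

Measured so far in a functional assay for inhibition, with Mus musculus as the target (on this read-out lower numbers stand for stronger inhibition and higher numbers for weaker inhibition), are two compounds
Compound 1 `C#CCN(Cc1cc2c(O)nc(C)nc2cc1C)c1ccc(C(=O)N[C@@H](CCC(=O)O)C(=O)N(C)[C@@H](CCC(=O)O)C(=O)O)c(F)c1` gives 1400 nM
Compound 2 `C#CCN(Cc1cc2c(O)nc(C)nc2cc1C)c1ccc(C(=O)N[C@@H](CCC(=O)O)C(=O)N(C)[C@@H](CCC(=O)O)C(=O)O)cc1` gives 2000 nM

Compound 1 shares the top of this short series with compound 2 and cannot be ranked ahead of it, since the step of a 1.4-fold higher number from compound 1 to compound 2 (0.15 log units; within the scatter) is the whole gap between them. That step is hydrogen in place of fluoro on an aromatic carbon.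

The next compound is compound 3 `C#CCN(Cc1cc2c(O)nc(C)nc2cc1C)c1ccc(C(=O)N[C@@H](CCC(=O)O)C(=O)N(CC)[C@@H](CCC(=O)O)C(=O)O)c(F)c1` and its change from compound 1 is methyl in place of hydrogen on a saturated chain carbon bound to an amide-type nitrogen in this assay terms. In words this is methyl in place of hydrogen on a saturated chain carbon bound to an amide-type nitrogen, so that methyl becomes ethyl.

Among the measured compounds shown here, no measured step touches this place. For the measured compounds named here, the single step available, at a different place in the molecule, shows only that one change there stayed inside the scatter. It offers no direction for the new change, and so no shift beyond the scatter is predicted. The expected step of a 1.3-fold higher number from compound 1 to compound 3 (0.11 log units; within the scatter) is an estimate with a wide margin on either side.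

Compound 3 is estimated at 1800 nM with an expected range from 600 nM to 5000 nM on this read-out.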

Compound 3, half-maximal inhibitory concentration: 220 nM
Estimate against measurement, compound 3: 8.2-fold (0.91 log units) above; the measured number lies below the stated range.
By their numbers in this assay, from the lowest: compound 3; then compounds 1 and 2 (each within the scatter of the next).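

In this assay, putting methyl in place of hydrogen on a saturated chain carbon bound to an amide-type nitrogen, which turns methyl into ethyl, gives a 6.4-fold lower number from compound 1 to compound 3 (0.80 log units; beyond the scatter). Among the compounds shown here, this is the first change to go beyond the scatter, whereas the only earlier step, at an aromatic carbon, was a 1.4-fold higher number from compound 1 to compound 2 (0.15 log units; within the scatter), so the (1,3-dicarboxypropyl)(methyl)amino part proves to be a place where adding one carbon moves the number toward stronger inhibition. Nothing available explains why this added carbon has such an effect on the read-out.

The compounds shown leave open whether the trend continues with a longer chain such as propyl or butyl, or holds for a branched isopropyl group, a cyclopropyl ring or a hydroxyethyl chain at the same nitrogen, since a single step from methyl to ethyl fixes only one point. For the compounds shown here, they also leave open whether ethyl has the same effect when hydrogen replaces fluoro on the aromatic carbon, as the two changes appear together in no pair here.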